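Ester variation on a shared core: Vero cytotoxicity

The source may report more compounds than this note shows. Statements on the series, on what has been measured and on what is new or still open speak of the compounds shown alone.

Compound 1 `O=C(OC1CCC(CN2CCN(c3cc(=O)c4cc(C(F)(F)F)cc([N+](=O)[O-])c4s3)CC2)CC1)C1CCC1`, compound 2 `O=C(OC1CCC(CN2CCN(c3cc(=O)c4cc(C(F)(F)F)cc([N+](=O)[O-])c4s3)CC2)CC1)c1ccc(F)cc1` and compound 3 `O=C(OC1CCC(CN2CCN(c3cc(=O)c4cc(C(F)(F)F)cc([N+](=O)[O-])c4s3)CC2)CC1)c1ccc2ccccc2c1` share one core and differ only in the group on the carbonyl carbon of the ester. In an ADME assay on Vero cells (Chlorocebus sabaeus) for cytotoxicity, read by MTT assay, with a stated time of 48 h (a higher number here means a weaker inhibitor, a lower number a stronger inhibitor), compound 1 gives > 64 ug/mL, which is a limit of the assay and not a number. Compound 2 gives > 64 ug/mL in this assay, likewise a limit. Compound 3 gives > 64 ug/mL in this assay, again a limit. Compound 3 thus stands at the limit, as the limit of > 64 ug/mL in this assay, at which 3 of the 3 values shown sit, records, and nothing separates it from compound 1 or compound 2 on the numbers shown.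

Compound 4 `COc1cccc(C(=O)OC2CCC(CN3CCN(c4cc(=O)c5cc(C(F)(F)F)cc([N+](=O)[O-])c5s4)CC3)CC2)c1` is reached from compound 3 by 3-methoxyphenyl in place of naphthalen-2-yl on a carbonyl carbon. The measured steps on this carbonyl carbon, a step that the two limits leave unreadable from compound 1 to compound 2, a step that the two limits leave unreadable from compound 1 to compound 3 and a step that the two limits leave unreadable from compound 2 to compound 3, are all unreadable in size because the limit of > 64 ug/mL in this assay, at which 3 of the 3 values shown sit, holds every value shown. They bear on the present change only in showing that cyclobutyl, 4-fluorophenyl and naphthalen-2-yl all leave the read-out at the limit. For compound 4 the step that the limit leaves unreadable from compound 3 to compound 4 is expected to be none beyond the scatter, and the assay most likely again reports only a limit. The estimate for compound 4 in this assay is 90 ug/mL, with a range from 45 ug/mL to 200 ug/mL.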

Compound 4, half-maximal inhibitory concentration: > 64 ug/mL
Compound 4: only a limit was reported; the forecaster's own chance of this, stated with the estimate: 85%; the middle value does not contradict the limit.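

In this assay compound 4 gives > 64 ug/mL, a limit and not a number. No step from compound 1, compound 2 or compound 3 to compound 4 can be read in size, because every value sits at one limit: the limit of > 64 ug/mL in this assay, at which 4 of the 4 values shown sit.

The compounds shown leave open whether the group on the carbonyl carbon affects the read-out at all.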